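This account rests on a few compounds, and the source may have more. Where it says the series, first, only, none or still open, it means among the compounds named here.

Measured so far:
compound 1 `CC1CCCCC1C(=O)N1CC(c2nc(-c3cccc(F)c3)no2)C1`: in an assay on HEK293 cells for negative allosteric modulation of metabotropic glutamate receptor 5 (Homo sapiens), read by FLIPR (a higher number here means a weaker inhibitor, a lower number a stronger inhibitor), compound 1 gives > 10000 nM, which is a limit of the assay and not a number.
compound 2 `CC1CCCC(C(=O)N2CC(c3nc(-c4cccc(Cl)c4)no3)C2)C1`: in this assay compound 2 gives > 10000 nM, again only a limit.

Compound 2 therefore stands at the limit of > 10000 nM in this assay, at which 2 of the 2 values shown sit, with no number of its own. Compound 3 `O=C(C1CCCO1)N1CC(c2nc(-c3cccc(Cl)c3)no2)C1` differs from it by oxolan-2-yl in place of 3-methylcyclohexyl on a carbonyl carbon. Within the data shown here, no step between measured neighbours is available; with both measured values resting at the limit, no change beyond the scatter is expected in this assay, in either direction. Compound 3 is expected near 15000 nM, within 3000 nM to 60000 nM, which amounts to an expected step that the limit leaves unreadable from compound 2 to compound 3.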

Compound 3, half-maximal inhibitory concentration: 890 nM
The estimate for compound 3 lay 17-fold (1.23 log units) above the measured number, outside the stated range (below it).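

In this assay the series now shows an at least 11-fold lower number from compound 2 to compound 3 (1.05 log units; beyond the scatter), with oxolan-2-yl in place of 3-methylcyclohexyl on a carbonyl carbon. The group at this place can therefore decide whether a number is readable at all. The full size of the step stays unknown because compound 2 rests at a limit, not a number: the limit of > 10000 nM in this assay, at which 2 of the 3 values shown sit.

From the compounds shown here alone, the change swaps ring size, ring oxygen and the methyl together, so which of these carries the step remains open. A cyclopentyl at this place would separate the smaller ring from the oxygen.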